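The source may report more compounds than this note shows. Statements on the series, on what has been measured and on what is new or still open speak of the compounds shown alone.

For the measured compounds named here, compound 2 `O=C(CCSc1nc2cc(Cl)ccc2o1)N1CCS(=O)(=O)C1` gives 8.9 mL/min/g in an ADME assay on microsomes from liver (Mus musculus) for metabolic stability, read by LC-MS, using NADPH, with a stated time of 45 min, tested at 0.5 uM (on this read-out lower numbers stand for slow clearance and higher numbers for fast clearance), and stands lowest of the two numbers so far; compound 1 `CCN(CC)C(=O)CCSc1nc2cc(Cl)ccc2o1` gives 108 mL/min/g in this assay. Going by the values given here, the single measured step, a 12-fold lower number from compound 1 to compound 2 (1.08 log units; beyond the scatter), bears directly on the change to compound 3 `CC1CCCN1C(=O)CCSc1nc2cc(Cl)ccc2o1`, which is 2-methylpyrrolidin-1-yl in place of 1,1-dioxo-1,3-thiazolidin-3-yl on a carbonyl carbon: the group that enters, like the diethylamino of compound 1, brings 0 hydrogen-bond donors and 0 hydrogen-bond acceptors. The number is therefore expected to move back toward compound 1, though perhaps not the whole way, as a 6.7-fold higher number from compound 2 to compound 3 (0.83 log units; beyond the scatter). Compound 3 is estimated at 60 mL/min/g, with a range from 25 mL/min/g to 150 mL/min/g.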

Compound 3, intrinsic clearance in a liver preparation (reported as CLH), per the amount of preparation that the assay uses: 98 mL/min/g
For compound 3 the middle estimate is 1.6-fold (0.21 log units) below the measured one, and the stated range covers the measured number.
By their numbers in this assay, from the lowest: compound 2; then compounds 3 and 1 (each within the scatter of the next).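

With the step of an 11-fold higher number from compound 2 to compound 3 (1.04 log units; beyond the scatter), the low number in this assay is tied, among the three groups on this carbonyl carbon, to 1,1-dioxo-1,3-thiazolidin-3-yl, and not to a five-membered non-aromatic ring as such, since 2-methylpyrrolidin-1-yl has one too. The step of a 1.1-fold lower number from compound 1 to compound 3 (0.04 log units; within the scatter) gives no separation between this ring and the open diethylamino group. Nothing available explains the difference.

Still open, going by these compounds, is whether a plain thiazolidine ring without the two oxo groups would keep the low number. A morpholine amide would also show whether a ring oxygen alone gives a similar result.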